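Phenyl to cyclopropyl on an alkyne across two related cores

This account rests on a few compounds, and the source may have more. Where it says the series, first, only, none or still open, it means among the compounds named here.

The set comprises two pairs of compounds built on two related cores. Compound 1 `O=C1Nc2c(ncn2Cc2ccccc2)C(C#Cc2ccccc2)N1Cc1ccccc1` and compound 2 `O=C1Nc2c(ncn2Cc2ccccc2)C(C#CC2CC2)N1Cc1ccccc1` share the first core; compound 3 `O=c1nc2c(ncn2Cc2ccccc2)c(C#Cc2ccccc2)n1Cc1ccccc1` and compound 4 `O=c1nc2c(ncn2Cc2ccccc2)c(C#CC2CC2)n1Cc1ccccc1` share the second. How the two cores differ is not broken down here.

In a functional assay on K562 cells (Homo sapiens) for cytotoxicity, read by thymidine incorporation, with a stated time of 48 h (a higher number here means a weaker inhibitor, a lower number a stronger inhibitor), compound 1 gives 0.8 ug/mL. Compound 2 carries cyclopropyl in place of phenyl on a triple-bonded carbon and gives 1.3 ug/mL in this assay, so that a 1.6-fold higher number from compound 1 to compound 2 (0.21 log units; within the scatter). Compound 3 gives 0.7 ug/mL in this assay, a value that sits close to that of compound 1 and within the scatter of compound 2 as well.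

Compound 4 has not yet been measured. It is related to compound 3 by cyclopropyl in place of phenyl on a triple-bonded carbon, and since the place of the change is described in the same words for both pairs, this is the same change as that from compound 1 to compound 2. Going by the values given here, the only guide to its size is the step already seen, which stayed within the scatter, so a step of about that size is expected again, a 1.6-fold higher number from compound 3 to compound 4 (0.20 log units; within the scatter), resting on a 1.6-fold higher number from compound 1 to compound 2 (0.21 log units; within the scatter) and on compound 3 giving 0.7 ug/mL. Compound 4 is therefore estimated to give 1.1 ug/mL in this assay, with a range from 0.5 ug/mL to 2.5 ug/mL.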

Compound 4, half-maximal inhibitory concentration: 0.2 ug/mL
Compound 4: the middle estimate sits 5.5-fold (0.74 log units) above what was measured, and the stated range ends above it.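

In this assay, cyclopropyl in place of phenyl on a triple-bonded carbon gives a 3.5-fold lower number from compound 3 to compound 4 (0.54 log units; beyond the scatter), a step that lies beyond the usual scatter on the core of compound 3. Set beside the step on the core of compound 1, the result shows that this change cannot be assumed to carry over from one of these cores to the other with the same size: the same change on two cores in this assay, a 1.6-fold higher number (0.21 log units; within the scatter) from compound 1 to compound 2 and a 3.5-fold lower number (0.54 log units; beyond the scatter) from compound 3 to compound 4, 5.7-fold (0.75 log units) apart, beyond the scatter of two such steps. The step on the core of compound 1 stays within the scatter, so a true reversal of direction is not shown, and with a single pair on each core the data do not show which difference between the cores goes with the gap, or whether it would recur with other groups.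

The compounds shown leave open how other groups on the triple-bonded carbon, such as a longer alkyl chain, an amine or a hydroxymethyl group, would behave on each core. They also leave open whether the gap between the two steps would remain if methyl stood in place of the benzyl groups that all four compounds carry.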